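A few compounds are considered here, and "the series" means these few. Any claim that something is new, unique, unknown or untested is made for them only; others in the source may bear on it.

Compound 2 `N[C@H]1CC[C@H](Nc2c(C(=O)NCc3ccc(F)cc3)nc(Br)c3cccnc23)CC1` gives 2000 nM in a functional assay on MCF7 cells (Homo sapiens) for cytotoxicity, read by MTT assay, with a stated time of 72 h (a higher number here means a weaker inhibitor, a lower number a stronger inhibitor), the lowest of the three numbers seen so far in the series. Compound 1 `CN(C)CCCNc1c(C(=O)NCc2ccc(F)cc2)nc(Br)c2cccnc12` gives 7000 nM, and compound 3 `N[C@H]1CC[C@H](Nc2c(C(=O)NCc3ccc(F)cc3)nc(N3CCCCC3)c3cccnc23)CC1` gives 5000 nM. The two measured steps are a 3.5-fold lower number from compound 1 to compound 2 (0.54 log units; beyond the scatter) and a 2.5-fold higher number from compound 2 to compound 3 (0.40 log units; beyond the scatter); both alter the amine side or the bromo position of the shared core and leave the benzylamide end untouched. Compound 4 `N[C@H]1CC[C@H](Nc2c(C(=O)NCc3cccs3)nc(Br)c3cccnc23)CC1` changes that end: thiophen-2-yl in place of 4-fluorophenyl on a saturated chain carbon bound to an amide-type nitrogen. Within the data shown here, no measured step bears on this part of the molecule, so the two known steps offer no direct guide, only the observation that changes elsewhere moved the number by modest amounts in either direction. With nothing pointing strongly one way, the expectation is a step of at most modest size, with a slight lean towards a higher number, and quite possibly none beyond the scatter. For compound 4 the estimate is 2800 nM, with a range from 1000 nM to 8000 nM; the step this implies is expected to be a 1.4-fold higher number from compound 2 to compound 4 (0.15 log units; within the scatter).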

Compound 4, half-maximal inhibitory concentration: 7300 nM
Beside the measured number, compound 4's estimate is 2.6-fold (0.42 log units) below it; low and high end bracket the measured number.
By their numbers in this assay, from the lowest: compound 2; then compounds 3, 1 and 4 (each within the scatter of the next).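

In this assay the benzylamide end proves not to be a silent part of the series: thiophen-2-yl in place of 4-fluorophenyl on a saturated chain carbon bound to an amide-type nitrogen brings a 3.7-fold higher number from compound 2 to compound 4 (0.56 log units; beyond the scatter). Among these compounds, the earlier steps touched only the amine side and the bromo position, so this is the first reading at this end, and it shows a step of modest size, beyond the scatter, with the 4-fluorophenyl group holding the lower number. No measurement at hand accounts for this step.

Still open, from the compounds shown here alone, is whether the step follows the loss of fluorine or the change of ring, which a plain phenyl or a furan-2-yl at this place would separate. Also open, going by these compounds, is whether it carries over to compounds with piperidin-1-yl in place of bromo.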